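The source may hold more compounds than are shown below. What is called first, only, known or untested is meant among the compounds shown, and "the series" means these compounds.

Compound 1 `O=C(O)[C@@H]1CCCN1C(=O)CN(c1nc(Cl)nc2[nH]cnc12)C1CC1`: 26%; compound 2 `NC(=O)C[C@H](NC(=O)CN(c1nc(Cl)nc2[nH]cnc12)C1CC1)C(=O)O`: 20.1%; compound 3 `O=C(O)CNC(=O)CN(c1nc(Cl)nc2[nH]cnc12)C1CC1`: 32.3%.

In a functional assay on the whole organism (Tail, strain ICR) with Mus musculus as the target, in the tail flick test, with a stated time of 90 min, at a dose of 25 umol/kg by the oral route (on this read-out higher numbers stand for a stronger effect at the one dose given and lower numbers for a weaker effect), compound 3 stands highest of the three numbers; one of the two steps that lead to it is a number 6.3 percentage points higher from compound 1 to compound 3 (within the scatter), and the other is a number 12.2 percentage points higher from compound 2 to compound 3 (beyond the scatter). Compound 4 `C[C@@H](O)[C@H](NC(=O)CN(c1nc(Cl)nc2[nH]cnc12)C1CC1)C(=O)O` differs from compound 3 by 1-hydroxyethyl in place of hydrogen on a saturated chain carbon bound to an amide-type nitrogen and a carbonyl carbon. The step that bears on this is the one at the same carbon, a number 12.2 percentage points higher from compound 2 to compound 3 (beyond the scatter), where a group at that place went with a modestly lower number. The step from compound 1 to compound 3 changes a different part and is within the scatter. The account therefore expects a modest fall, a number 8.3 percentage points lower from compound 3 to compound 4 (within the scatter), for compound 4. Compound 4 is estimated at 24%, within 13% to 35%.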

Compound 4, a percentage reported as activity, at one dose (the size of the read-out at that dose, not a potency): 35.9%
For compound 4 the middle estimate is 11.9 percentage points below the measured one; the whole stated range lies below it.
By their numbers in this assay, from the lowest: compounds 2, 1, 3 and 4 (each within the scatter of the next, the first and the last beyond it).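

In this assay, 1-hydroxyethyl in place of hydrogen on a saturated chain carbon bound to an amide-type nitrogen and a carbonyl carbon gives a number 3.6 percentage points higher from compound 3 to compound 4 (within the scatter), so a group at this carbon need not go with a lower number, as compound 2 alone had suggested. The group's identity counts here, since 1-hydroxyethyl in place of carbamoylmethyl gives a number 15.8 percentage points higher from compound 2 to compound 4 (beyond the scatter), whereas the change in the whole amino acid part gives a number 9.9 percentage points higher from compound 1 to compound 4 (within the scatter). Nothing available explains these results. The compounds shown leave open whether the hydroxyl of 1-hydroxyethyl matters, as a plain ethyl group would show, and how a longer chain or an amine at this carbon would read.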